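The source may report more compounds than this note shows. Statements on the series, on what has been measured and on what is new or still open speak of the compounds shown alone.

Measured in a functional assay on HEL cells (Homo sapiens); on this read-out higher numbers stand for lower toxicity in this test and lower numbers for higher toxicity in this test:
- Compound 1 `CCCCc1cc2cn(COCCO)c(=O)nc2o1`: > 200000 nM
- Compound 2 `CCCCCCCc1cc2cn(COCCO)c(=O)nc2o1`: 140000 nM

The entry for compound 1 is a limit of the test, not a number. Within the data shown here, compound 2, at 140000 nM, holds the only true number in this assay, so it has no measured number to be ranked against. Compound 3 `CCCCCCCCCc1cc2cn(COCCO)c(=O)nc2o1` lengthens the same chain: ethyl in place of hydrogen on a saturated chain carbon, seven bonds along the chain from an aromatic carbon. Among the measured compounds shown here, the one measured step that bears on this is an at least 1.4-fold lower number from compound 1 to compound 2 (0.15 log units; that floor lies within the scatter). That step gives only a weak hint of direction, so a small move towards lower numbers is expected. The expected step is a 2.0-fold lower number from compound 2 to compound 3 (0.30 log units; within the scatter). For compound 3 the estimate is 70000 nM, with an expected range of 25000 nM to 200000 nM.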

Compound 3, half-maximal cytotoxic concentration: >= 100000 nM
Compound 3 ended at the assay's limit; the forecaster's own chance of this, stated with the estimate: 20%; at least 1.4-fold (0.15 log units) between middle value and limit.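

Among these compounds, the entry for compound 3 in this assay is a limit, not a number, so no step from compound 1 or compound 2 to compound 3 can be read. Going by these compounds, whether lengthening the chain of compound 2 changes toxicity stays open.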